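Methoxy in place of hydrogen: compound 1 to compound 4

A few compounds are considered here, and "the series" means these few. Any claim that something is new, unique, unknown or untested is made for them only; others in the source may bear on it.

In an ADME assay on MT4 cells (Homo sapiens) for cytotoxicity, with a stated time of 3 days (a lower number here means that less compound is tolerated, a higher number that more compound is tolerated), compound 1 `Cc1cc(/C=C/C#N)ccc1Nc1ccnc(Nc2ccc(C#N)cc2)n1` gives > 25000 nM, which is a limit and not a number. Compound 2 `N#C/C=C/c1ccc(Nc2ccnc(Nc3ccc(C#N)cc3)n2)cc1` gives > 25000 nM, also a limit. Compound 3 `Cc1cc(/C=C\C#N)cc(C)c1Sc1ccnc(Nc2ccc(C#N)cc2)n1` gives > 25000 nM, again a limit. The measured set therefore shows (the limit of > 25000 nM in this assay, at which 3 of the 3 values shown sit), and compound 1 has no readable position within it.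

Compound 4 `COc1cc(/C=C/C#N)cc(C)c1Nc1ccnc(Nc2ccc(C#N)cc2)n1` differs from compound 1 by methoxy in place of hydrogen on an aromatic carbon. The new group stands ortho to a large group, meta to a 2-cyanoethenyl group and meta to a methyl group.

For the measured compounds named here, the only measured step that bears on this change is a step that the two limits leave unreadable from compound 1 to compound 2, which puts hydrogen in place of methyl on an aromatic carbon. That step offers no size to carry over, and it concerns a different group. The expectation in this assay therefore rests on (the limit of > 25000 nM in this assay, at which 3 of the 3 values shown sit), and it points in no direction. The expected size is a number no higher from compound 1 to compound 4 (the limit leaves the size open), with no change beyond the scatter. Compound 4 is most likely to be reported as a limit too. As a value, compound 4 is estimated at 25000 nM, with an expected range from 9000 nM to 50000 nM.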

Compound 4, half-maximal cytotoxic concentration: 633 nM
Estimate against measurement, compound 4: 39-fold (1.60 log units) above; measured number below the stated range.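

Methoxy in place of hydrogen on this aromatic carbon, ortho to a large group, meta to a 2-cyanoethenyl group and meta to a methyl group, gives the first step of readable size in the series in this assay: an at least 39-fold lower number from compound 1 to compound 4 (1.59 log units; beyond the scatter). For the compounds shown here, this position is therefore not silent in this assay, and here the change goes towards less compound being tolerated, which the earlier compounds could not show. Going by these compounds alone, compound 4 is also the only compound in the set that yields a number rather than a limit: the limit of > 25000 nM in this assay, at which 3 of the 4 values shown sit.

The full size of the step remains open, since only its lower bound can be read, and nothing shown gives a cause for it. As far as these compounds go, it is also open whether the effect belongs to methoxy itself or to substitution at this carbon more generally, a question that a hydroxyl, an ethoxy group, a chlorine or an amine at the same place would address, along with whether the step holds without the methyl group or with the sulfur link of compound 3.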